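The source may report more compounds than this note shows. Statements on the series, on what has been measured and on what is new or still open speak of the compounds shown alone.

Measured so far:
compound 1 `Cc1cccc(C#Cc2ccc3c(n2)CCN(C(C)C)C3=O)c1`: 510 nM
compound 2 `O=C1c2ccc(C#Cc3ccccc3)nc2CCN1C1CCCC1`: 890 nM

Both numbers come from an assay on HEK293 cells for displacement of a labelled ligand from metabotropic glutamate receptor 5 (Homo sapiens), with a stated time of 2 h; a higher number here means a weaker inhibitor, a lower number a stronger inhibitor; in that assay compound 1 gives 510 nM and compound 2 gives 890 nM. Compound 2 has the highest of the two numbers, but its nearest neighbour, compound 1, lies within the scatter, so the two are not told apart. Going by the values given here, compound 1 and compound 2 differ from each other in more than one place, and no single step between measured compounds is available.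

Compound 3 `Cc1cccc(C#Cc2ccc3c(n2)CCN(C2CCCC2)C3=O)c1` is not yet measured. It differs from compound 2 by methyl in place of hydrogen on an aromatic carbon. Among the compounds with values here, no measured pair isolates that change, so the size of its step in this assay is open; a step no larger than the scatter, in either direction, is expected. For compound 3 the expected value in this assay is 550 nM, with a range from 180 nM to 1700 nM. The expected step of a 1.6-fold lower number from compound 2 to compound 3 (0.21 log units; within the scatter) is a slight move toward a lower number that stays within the scatter.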

Compound 3, inhibition constant: 670 nM
Compound 3: middle estimate off by 1.2-fold (0.09 log units), on the low side, and the stated range covers the measured number.
By their numbers in this assay, from the lowest: compounds 1, 3 and 2 (each within the scatter of the next).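

Phenyl to 3-methylphenyl now has a pair of its own in this assay: with a 1.3-fold lower number from compound 2 to compound 3 (0.12 log units; within the scatter) as the step, methyl in place of hydrogen at this place, meta to a large group, cannot be told from no change. Cyclopentyl in place of isopropyl on the amide-type nitrogen in a ring also gets a pair that isolates it, and a 1.3-fold higher number from compound 1 to compound 3 (0.12 log units; within the scatter) likewise leaves the two groups untold apart. No evidence on the cause of either step is available here.

Going by these compounds, whether a larger or different group on the aromatic ring, such as methoxy or an amine, would give a step beyond the scatter stays open. On the nitrogen, the same holds for a longer chain or a group carrying a carboxylic acid.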